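Methyl in Place of Bromo: What Is Expected of Compound 3

This account rests on a few compounds, and the source may have more. Where it says the series, first, only, none or still open, it means among the compounds named here.

Compound 2 `Brc1ccccc1OCC1=NCCO1` was examined in a toxicity assay on the whole organism with Rattus norvegicus as the target, at a dose of 100 mg/kg by the oral route (on this read-out lower numbers stand for a weaker effect and higher numbers for a stronger effect at the one dose given), where compound 2 gives 10%. For the measured compounds named here, only one other number stands beside it: compound 1 `COc1ccc(OCC2=NCCO2)cc1` gives 5% in this assay. On paper the number of compound 2 is the larger of the two, yet the gap to compound 1 lies within the usual scatter of such measurements, so the two compounds cannot be told apart, and both show a weak effect at the one dose given.

Compound 3 `Cc1ccccc1OCC1=NCCO1` has not yet been measured. It differs from compound 2 in one place: methyl in place of bromo on an aromatic carbon. Going by the values given here, no step between measured compounds is known that would show how such a change acts in this assay, and the two numbers recorded leave the whole series at a low level. The step from compound 2 to compound 3 is therefore expected to be a number 2 percentage points lower from compound 2 to compound 3 (within the scatter), that is, nothing beyond the scatter. Compound 3 is estimated to give 8%, with a range from 0% to 25%.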

Compound 3, a percentage reported as activity, at one dose (the size of the read-out at that dose, not a potency): 10%
For compound 3 the middle estimate is 2 percentage points below the measured one; measured number inside the range.
By their numbers in this assay, from the lowest: compounds 1, 2 and 3 (each within the scatter of the next).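

Methyl in place of bromo, on an aromatic carbon ortho to a group of 7 heavy atoms, provides the one step in this series that can be read in this assay: the result is no change at the digits printed from compound 2 to compound 3 (within the scatter). For the compounds shown here, the earlier compounds could show only two numbers side by side, whereas this pair isolates a single place, and exchanging one heavy atom there, a bromine for a carbon, leaves the read-out at the same low level at the one dose given. No measurement available explains why these two groups read alike, and the result rests on this one exchange alone.

The compounds shown leave open whether a different group at this same place, such as an amine, a carboxylic acid or a longer chain, would move the number beyond the scatter or leave it at this low level. They also leave open whether methyl in place of bromo would read the same way at another carbon of the ring, and how any such step would appear at a dose other than the one used here.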